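Replacing a dichlorophenyl hydrazone with a hydroxynaphthyl one

The source may report more compounds than this note shows. Statements on the series, on what has been measured and on what is new or still open speak of the compounds shown alone.

In an ADME assay on WI-38 cells (Homo sapiens) for cytotoxicity, read by MTT assay, with a stated time of 72 h (a lower number here means a stronger inhibitor, a higher number a weaker inhibitor), compound 2 `CN(C)CCn1cnnc1-c1cc(Oc2ccc(NC(=O)N/N=C/c3cccc(Cl)c3Cl)cc2F)ccn1` gives 6130 nM. Going by the values given here, the only other measured compound, compound 1 `CN(C)CCn1cnnc1-c1cc(Oc2ccc(NC(=O)N/N=C/c3ccc(Cl)cc3Cl)cc2F)ccn1`, gives 4760 nM in this assay, and the step of a 1.3-fold higher number from compound 1 to compound 2 (0.11 log units; within the scatter) shows that moving one chlorine on that ring leaves the number essentially unchanged. Compound 3 `CN(C)CCn1cnnc1-c1cc(Oc2ccc(NC(=O)N/N=C/c3c(O)ccc4ccccc34)cc2F)ccn1` differs from compound 2 by 2-hydroxynaphthalen-1-yl in place of 2,3-dichlorophenyl on a carbon with a double bond to nitrogen. Among the compounds with values here, no measured step covers a change of this kind: the single step available only shifts a chlorine within one ring, whereas here a second ring and a hydroxyl enter and both chlorines leave. Within the data shown here, with no direct precedent, the expectation for compound 3 is a number close to that of compound 2, estimated as a 1.0-fold lower number from compound 2 to compound 3 (0.01 log units; within the scatter), with a wide range to reflect the uncertainty. Compound 3 is therefore estimated at 6000 nM, with a range from 2000 nM to 18000 nM.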

Compound 3, half-maximal inhibitory concentration: 3250 nM
The estimate for compound 3 lay 1.8-fold (0.27 log units) above the measured number, within the range that was stated.
By their numbers in this assay, from the lowest: compounds 3, 1 and 2 (each within the scatter of the next).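

In this assay the 2-hydroxynaphthalen-1-yl group gives a 1.9-fold lower number from compound 2 to compound 3 (0.28 log units; within the scatter) when it takes the place of 2,3-dichlorophenyl, and a 1.5-fold lower number from compound 1 to compound 3 (0.17 log units; within the scatter) when it takes the place of 2,4-dichlorophenyl. Until now this position, on a carbon with a double bond to nitrogen, had been tested only by moving one chlorine, whereas here both chlorines leave and a second ring and a hydroxyl enter, and the numbers still stay within the scatter of each other. No measurement is available to explain this result.

The compounds shown leave open how the second ring and the hydroxyl each count on their own, which a plain naphthalen-1-yl group or a hydroxyphenyl group would separate. Also open, from the compounds shown here alone, is whether any group at this place, such as a ring carrying an amine or a carboxylic acid, moves the number in this assay beyond the scatter.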